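The compounds below may be only part of what the source reports. "The series", "measured", "known", "first", "only" and "open" are said of these compounds alone.

Compound 1 `CC(C)c1onc(-c2c(Cl)cccc2Cl)c1COc1ccc(-c2nc3ccc(C(=O)O)cc3n2CC(C)(C)C)cc1`: in an assay on HEK-293T cells for antagonist activity at vitamin D3 receptor (Homo sapiens), read by a luciferase reporter, with a stated time of 24 h (on this read-out higher numbers stand for weaker inhibition and lower numbers for stronger inhibition), compound 1 gives 861 nM.
Compound 2 `CC(=O)N1CCC(n2c(-c3ccc(OCc4c(-c5c(Cl)cccc5Cl)noc4C(C)C)cc3)nc3ccc(C(=O)O)cc32)CC1`: in this assay compound 2 reaches only a limit of the assay, > 10000 nM.

Compound 2 thus sits at the limit of > 10000 nM in this assay, at which 1 of the 2 values shown sits, the weaker end of the two values shown, and its result is a limit rather than a number. Compound 3 `CC(C)c1onc(-c2c(Cl)cccc2Cl)c1COc1ccc(-c2nc3ccc(C(=O)O)cc3n2C2CCCC2)cc1` differs from it by cyclopentyl in place of 1-acetylpiperidin-4-yl on an aromatic nitrogen. Within the data shown here, the one measured step that bears on this place is an at least 11-fold higher number from compound 1 to compound 2 (1.06 log units; beyond the scatter), which shows that exchanging a carbon-only group on the aromatic nitrogen for 1-acetylpiperidin-4-yl drove the number up sharply. Compound 3 returns to a carbon-only group, cyclopentyl, so a large step back toward stronger inhibition is expected, an at least 6.6-fold lower number from compound 2 to compound 3 (0.82 log units; beyond the scatter). Whether it fully regains the level of compound 1 is uncertain. Compound 3 is therefore estimated at 1500 nM, with a likely range from 500 nM to 6000 nM.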

Compound 3, half-maximal inhibitory concentration: 929 nM
For compound 3 the middle estimate is 1.6-fold (0.21 log units) above the measured one; the range from low to high includes it.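

In this assay, the return to a carbon-only group gives an at least 10-fold lower number from compound 2 to compound 3 (1.03 log units; beyond the scatter), so on this aromatic nitrogen the loss seen with 1-acetylpiperidin-4-yl does not persist once cyclopentyl stands there. The result for compound 2 is a limit of the assay and not a number: the limit of > 10000 nM in this assay, at which 1 of the 3 values shown sits. Neopentyl and cyclopentyl are not told apart, with a 1.1-fold higher number from compound 1 to compound 3 (0.03 log units; within the scatter), so these two different carbon-only groups serve alike at this place.

The compounds shown leave open which part of 1-acetylpiperidin-4-yl goes with the loss, the acetyl or the ring nitrogen, a question that a free piperidin-4-yl or a cyclohexyl on this nitrogen would bear on. They also leave open how a much smaller carbon-only group, such as methyl, would fare here.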